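Compound 3 to Compound 4: Expected Tolerance on Vero Cells

The source may hold more compounds than are shown below. What is called first, only, known or untested is meant among the compounds shown, and "the series" means these compounds.

Measured compounds:
- compound 1, `CC/C(C)=N\NC(=S)N(Cc1ccccc1)Cc1ccccc1`: compound 1 gives "not determined" (no result reported)
- compound 2, `C=CCN(CC=C)C(=S)N/N=C(/C)CC`: compound 2 gives "not determined" (no result reported)
- compound 3, `C=CCN(CC=C)C(=S)N/N=C(/C)c1ccccc1`: in an ADME assay on Vero cells (Chlorocebus sabaeus) for cytotoxicity, read by MTT assay, with a stated time of 72 h (a lower number here means that less compound is tolerated, a higher number that more compound is tolerated), compound 3 gives 229000 nM

Of the three compounds, only compound 3 carries a number in this assay; for compound 1 and compound 2 no result was reported, so compound 3 stands alone and cannot be ranked against them. The unmeasured compound 4, `C=CCN(CC=C)C(=S)N/N=C(/C)c1ccc(O)cc1`, differs from compound 3 in one place: hydroxy in place of hydrogen on an aromatic carbon. Among the measured compounds shown here, no pair of measured compounds shows what such a change does in this assay, so there is no measured step to lean on. For the measured compounds named here, the only anchor is the value of compound 3, and from that anchor the step is expected to be small, a 1.0-fold higher number from compound 3 to compound 4 (0.00 log units; within the scatter), not beyond the usual scatter in either direction. Compound 4 is therefore estimated at 230000 nM, with a range from 100000 nM to 500000 nM.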

Compound 4, half-maximal cytotoxic concentration: 216000 nM
Compound 4: the middle estimate sits 1.1-fold (0.03 log units) above what was measured; low and high end bracket the measured number.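

In this assay, among the compounds shown here, hydroxy in place of hydrogen on an aromatic carbon, para to a large group, gives a 1.1-fold lower number from compound 3 to compound 4 (0.03 log units; within the scatter) and is the only step that can be read here. At this position on the six-membered aromatic ring, adding this one group therefore leaves the tolerated concentration indistinguishable within the usual scatter of this read-out. This holds for this single pair and does not establish a wider pattern.

Going by these compounds, it remains open whether an amine, a methoxy group or a carboxylic acid at the same position would also stay within the scatter. Steps involving compound 1 or compound 2 cannot be read, as neither has a numerical result. No supporting evidence is available to explain this result.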